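The compounds below may be only part of what the source reports. "The series", "measured", "known", "first", "only" and "open" are said of these compounds alone.

Of the compounds shown here, two carry numbers so far. In a functional assay on the whole organism with Mus musculus as the target (on this read-out lower numbers stand for an effect already at smaller amounts and higher numbers for an effect only at larger amounts of compound), compound 1 `NC(=O)/C=C1\CCc2ccc(Br)cc21` gives 96 mg/kg, and compound 2 `O=C(/C=C1\CCc2c(F)ccc(F)c21)NC1CC1` gives 59 mg/kg. These two values lie within the scatter of each other, so compound 1 has no separate standing on these numbers. Among the compounds with values here, no step between measured compounds that differ in one place is available, which leaves the size of any single change in this assay uncalibrated.

The next entry is compound 3 `NC(=O)/C=C1\CCc2ccc(F)cc21`, not yet measured in this assay. It has fluoro in place of bromo on an aromatic carbon, meta to a fused ring and para to a fused ring: fluoro in place of bromo on an aromatic carbon. Compound 2, also a fluoro compound, gives 59 mg/kg, so the available values offer no reason to expect a large shift. The estimated step of a 1.3-fold lower number from compound 1 to compound 3 (0.11 log units; within the scatter) is expected to stay within the scatter, with no firm direction. Compound 3 is estimated at 75 mg/kg, with an expected range of 30 mg/kg to 190 mg/kg.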

Compound 3, dose for half-maximal effect: 56 mg/kg
For compound 3 the middle estimate is 1.3-fold (0.13 log units) above the measured one; the measured number falls inside the stated range.
By their numbers in this assay, from the lowest: compounds 3, 2 and 1 (each within the scatter of the next).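

Fluoro in place of bromo, on an aromatic carbon meta to a fused ring and para to a fused ring, gives the first single change that can be read in this assay, with a 1.7-fold lower number from compound 1 to compound 3 (0.23 log units; within the scatter) as its size. Within the data shown here, this exchange of one halogen for another, with no change in the counts of rings, hydrogen-bond donors, hydrogen-bond acceptors or net charge, therefore does not separate the two compounds on this read-out, and it gives the series a first calibration for a change at this position. No supporting measurement bears on why the two halogens read alike.

Going by these compounds, whether a group of another kind at this position, such as methoxy, an amine or a nitrile, would give a step beyond the scatter remains open. Compound 2 differs from compound 3 in more than one place, so steps to it cannot be read, and the separate contributions of its cyclopropyl group on the amide nitrogen and of its fluoro pattern on the aromatic ring remain unresolved.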